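This account rests on a few compounds, and the source may have more. Where it says the series, first, only, none or still open, it means among the compounds named here.

Compound 1 `CC(C)(C)c1ccc(NC(=S)N2CCN(c3ncccc3C(F)(F)F)CC2)cc1` — in a functional assay on HEK293 cells for antagonist activity at transient receptor potential cation channel subfamily V member 1 (Rattus norvegicus) (a lower number here means a stronger inhibitor, a higher number a weaker inhibitor), compound 1 gives 246 nM.
Compound 2 `CC(C)c1ccc(NC(=O)N2CCN(c3ncccc3Cl)CC2)cc1` — in this assay compound 2 gives 11.5 nM.

Of the two measured compounds, compound 2 holds the lower number, and the gap to compound 1 lies well beyond the usual scatter. Compound 3 `CCc1cccnc1N1CCN(C(=O)Nc2ccc(C(C)C)cc2)CC1` differs from compound 2 in one place: ethyl in place of chloro on an aromatic carbon. Going by the values given here, no measured pair shows this change alone, so the expected step is small, likely within the scatter or a modest rise, and the estimated step is a 1.7-fold higher number from compound 2 to compound 3 (0.24 log units; within the scatter). Compound 3 is therefore expected to give about 20 nM in this assay, with a plausible range from 6 nM to 70 nM.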

Compound 3, half-maximal inhibitory concentration: 230 nM
Compound 3: middle estimate off by 12-fold (1.06 log units), on the low side; measured number outside the range, above it.
By their numbers in this assay, from the lowest: compound 2; then compounds 3 and 1 (each within the scatter of the next).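

The change from 3-chloropyridin-2-yl to 3-ethylpyridin-2-yl gives a 20-fold higher number from compound 2 to compound 3 (1.30 log units; beyond the scatter) in this assay and is the only single-place comparison shown. It shows that this aromatic carbon, ortho to a large group and two atoms from the ring nitrogen, does not accept ethyl in place of chloro without a large loss of inhibition. Nothing measured here accounts for that loss. The compounds shown leave open whether methyl, methoxy or an amine at this same position would stay close to compound 2 or move toward compound 3.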